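Methyl to Hydroxy on the Pendant Ring of Compound 3

This account rests on a few compounds, and the source may have more. Where it says the series, first, only, none or still open, it means among the compounds named here.

Compound 3 `Cc1cc(-c2nc(-c3ccc4[nH]c(=O)oc4c3)cs2)ccc1F` shares its core with compound 1 `O=c1[nH]c2ccc(-c3csc(-c4ccccc4)n3)cc2o1` and compound 2 `N#Cc1ccc(-c2nc(-c3ccc4[nH]c(=O)oc4c3)cs2)cc1`. In an assay on isolated protein for inhibition of protein phosphatase 1D (Homo sapiens), read by malachite green (a lower number here means a stronger inhibitor, a higher number a weaker inhibitor), compound 3 gives < 20000 nM, which is a limit of the assay rather than a number. Compound 1 gives < 20000 nM, likewise a limit. Compound 2 gives < 20000 nM, again a limit. Compound 3 therefore stands nowhere apart from its neighbours: all three values rest at the same limit, as recorded in the limit of < 20000 nM in this assay, at which 3 of the 3 values shown sit. Within the data shown here, the single measured step between them, a step that the two limits leave unreadable from compound 1 to compound 2, has a size that the two limits leave unreadable, and it concerns a cyano rather than the group altered here.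

Compound 4 `O=c1[nH]c2ccc(-c3csc(-c4ccc(F)c(O)c4)n3)cc2o1` differs from compound 3 by hydroxy in place of methyl on an aromatic carbon. No measured step touches a methyl or a hydroxy, so the measured compounds give no direction for this change, and with every shown value sitting at the limit there is no number from which a step could be read. The step that the limit leaves unreadable from compound 3 to compound 4 is therefore expected to be small, with no direction beyond the scatter claimed. Compound 4 is expected to give about 5000 nM in this assay, within a range from 500 nM to 20000 nM, with a real chance that only a limit is reported once more.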

Compound 4, half-maximal inhibitory concentration: < 20000 nM
Compound 4: only a limit was reported (the forecaster's own chance of this, stated with the estimate: 65%); the middle value lies beyond the limit too.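

No step can be read from compound 3 to compound 4, because each of them gives only a limit in this assay: the limit of < 20000 nM in this assay, at which 4 of the 4 values shown sit. The compounds shown leave open how strongly any of them actually inhibits, and whether hydroxy in place of methyl on an aromatic carbon makes any difference in this assay.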